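Removal of a core chloro group in the bis-chloro series

This account rests on a few compounds, and the source may have more. Where it says the series, first, only, none or still open, it means among the compounds named here.

Measured so far:
compound 1 `Nc1nc(Cl)c2ncn(Cc3ccc(CCl)cc3)c2n1` — > 100000 nM
compound 2 `ClCc1cccc(Cn2cnc3nc(Cl)nc(Cl)c32)c1` — 970 nM
compound 3 `ClCc1ccc(Cn2cnc3ncnc(Cl)c32)cc1` — "not determined" (no result reported)

The read-out throughout is a functional assay on SK-MEL-28 cells (Homo sapiens) for cytotoxicity, read by sulforhodamine B assay, with a stated time of 48 h; on this read-out higher numbers stand for lower toxicity in this test and lower numbers for higher toxicity in this test. Going by the values given here, compound 2 gives 970 nM and is the only compound with a number in this assay. Compound 1 gives > 100000 nM, which is a limit of the assay rather than a number. Compound 3 has no result reported in this assay. Among the three entries shown, therefore, compound 2 stands as the single measured point, with one further value sitting at a limit of > 100000 nM in this assay, at which 1 of the 3 values shown sits, and one further entry empty.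

The next compound, compound 4 `ClCc1cccc(Cn2cnc3ncnc(Cl)c32)c1`, differs from compound 2 in one place:
hydrogen in place of chloro on an aromatic carbon
Among the compounds with values here, no step between two measured compounds is available to calibrate this change, so the expectation rests on compound 2 alone and on the fact that compound 1, which also lacks a second chloro on the core, sits at a limit. The step from compound 2 to compound 4 is expected to run toward higher numbers, beyond the scatter, as a 6.2-fold higher number from compound 2 to compound 4 (0.79 log units; beyond the scatter). Compound 4 is estimated at 6000 nM, with a range from 1200 nM to 40000 nM, and a real chance that only a limit is returned.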

Compound 4, concentration lethal to 50% of the cells: 42700 nM
Estimate against measurement, compound 4: 7.1-fold (0.85 log units) below; measured number above the stated range.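

In this assay, going by these compounds alone, this is the first step that can be read, and it is large: hydrogen in place of chloro on an aromatic carbon, at the position between two ring nitrogen atoms, gives a 44-fold higher number from compound 2 to compound 4 (1.64 log units; beyond the scatter). On this read-out the higher number stands for lower toxicity in this test, so in this one pair the chloro at that position accounts for a large part of the number seen for compound 2, while compound 4 still returns a number rather than a limit. Nothing shown gives a reason for the size of this step.

Within the data shown here, compound 1 gives > 100000 nM, a limit of the assay and not a number, so it supplies no step to set beside this one. On these data alone, it remains open whether a methyl or a methoxy group at the same position would stay close to compound 2 or close to compound 4, and whether the step holds with the chloromethyl arrangement of compound 3, which has no result.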